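Phenyl for Methyl on Two Related Cores

The source may hold more compounds than are shown below. What is called first, only, known or untested is meant among the compounds shown, and "the series" means these compounds.

Measured compounds in a functional assay on HL-60 cells (Homo sapiens) for inhibition; a lower number here means a stronger inhibitor of growth, a higher number a weaker inhibitor of growth:
compound 1, `C=C(C)C(=O)c1ccc(OCc2nc(C)no2)c(C)c1C`, gives 3200 nM
compound 2, `C=C(C)C(=O)c1ccc(OCc2nc(-c3ccccc3)no2)c(C)c1C`, gives 3500 nM
compound 3, `C=C(C)C(=O)c1ccc(OCc2nc(C)no2)cc1Cl`, gives 9700 nM

Three compounds share a common arrangement: a methacryloyl group on a benzene ring, with a five-membered ring attached through an ether linkage. Compound 1 and compound 2 share one core and differ only by phenyl in place of methyl on an aromatic carbon. This change made a 1.1-fold higher number from compound 1 to compound 2 (0.04 log units; within the scatter), so in this assay compound 1 and compound 2 cannot be told apart. Compound 3 carries a different core; how its core differs from that of compound 1 is not broken down here. In this assay compound 3 has the highest number of the three, with both other compounds lying beyond the scatter of it.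

Compound 4, `C=C(C)C(=O)c1ccc(OCc2nc(-c3ccccc3)no2)cc1Cl`, has not yet been measured. It stands to compound 3 as compound 2 stands to compound 1: the difference is phenyl in place of methyl on an aromatic carbon, and the place of the change is described in the same words for both pairs, so this is the same change. Within the data shown here, since the only measured instance of this change, from compound 1 to compound 2, stayed within the scatter, a comparably small step is expected from compound 3 to compound 4 in this assay, namely a 1.1-fold higher number from compound 3 to compound 4 (0.03 log units; within the scatter). Compound 4 is therefore estimated at 10500 nM, expected to lie between 5000 nM and 22000 nM. This rests on a single measured pair, so the expectation is held loosely.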

Compound 4, concentration for 50% growth inhibition: 5400 nM
For compound 4 the middle estimate is 1.9-fold (0.29 log units) above the measured one, within the range that was stated.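

In this assay, putting phenyl in place of methyl on the five-membered ring of compound 3 gave a 1.8-fold lower number from compound 3 to compound 4 (0.25 log units; within the scatter), a step within the scatter, so compound 3 and compound 4 cannot be told apart, just as compound 1 and compound 2 could not. The useful result is that the two steps also cannot be told apart, so on these two cores the swap behaves alike and leaves no readable trace on growth inhibition: the same change on two cores in this assay, a 1.1-fold higher number (0.04 log units; within the scatter) from compound 1 to compound 2 and a 1.8-fold lower number (0.25 log units; within the scatter) from compound 3 to compound 4, 2.0-fold (0.29 log units) apart, within the scatter of two such steps. Among these compounds, this supports carrying the change between these two cores with the expectation of a small step, but it rests on only two pairs, and it shows neither that the same would hold on a third core nor why the swap makes so little difference here.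

As far as these compounds go, only methyl and phenyl stand at this place on the five-membered ring, so it remains open whether an amine, a carboxylic acid or a longer chain there would also leave the number in the scatter or shift it clearly. All four compounds also carry the methacryloyl group, so what happens when another group, such as a plain acetyl, takes its place is open as well.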